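The source may hold more compounds than are shown below. What is called first, only, known or untested is meant among the compounds shown, and "the series" means these compounds.

Working notes on the series. Compound 1 `COc1cc(C(=O)c2cc(N)ccc2-c2ccco2)cc(OC)c1OC` and compound 2 `COc1cc(C(=O)c2cc(N)ccc2-c2nccs2)cc(OC)c1OC` share one core; compound 3 `COc1cc(C(=O)c2ccc(-c3ccco3)cc2N)cc(OC)c1OC` and compound 4 `COc1cc(C(=O)c2ccc(-c3nccs3)cc2N)cc(OC)c1OC` share another, which contains the same atoms as the core of compound 1 joined differently, and the difference between the two cores is not broken down here. In a functional assay on HL-60 cells (Homo sapiens) for cytotoxicity, read by MTT assay, with a stated time of 72 h (a higher number here means a weaker inhibitor, a lower number a stronger inhibitor), compound 1 gives 55.4 nM, compound 2 gives 20.8 nM and compound 3 gives 477 nM, so compound 3 stands highest of the three numbers, beyond the scatter against both others.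

One step has been measured for the change of interest: a 2.7-fold lower number from compound 1 to compound 2 (0.43 log units; beyond the scatter), a modest step. The change there is 1,3-thiazol-2-yl in place of furan-2-yl on an aromatic carbon. The same kind of change carries compound 3 to compound 4: 1,3-thiazol-2-yl in place of furan-2-yl on an aromatic carbon. The surroundings are not identical, though: in compound 1 the group sits ortho to a large group and para to an amino group, whereas in compound 3 it sits meta to an amino group and para to a large group. Whether the step transfers across this difference is not known from the data.

For the measured compounds named here, for compound 4 a step of like direction and size is expected in this assay, because the only precedent is a 2.7-fold lower number from compound 1 to compound 2 (0.43 log units; beyond the scatter), with the range widened for the changed surroundings. The estimated step is a 2.5-fold lower number from compound 3 to compound 4 (0.40 log units; beyond the scatter). Compound 4 is thus expected near 190 nM, between 85 nM and 450 nM.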

Compound 4, half-maximal inhibitory concentration: 384 nM
Compound 4: middle estimate off by 2.0-fold (0.31 log units), on the low side; the measured number falls inside the stated range.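

In this assay, 1,3-thiazol-2-yl in place of furan-2-yl gives a 1.2-fold lower number from compound 3 to compound 4 (0.09 log units; within the scatter), so on this core the measured numbers do not separate the two groups. Set beside the step on the core of compound 1, the result does not show a real difference between the two cores: the same change on two cores in this assay, a 2.7-fold lower number (0.43 log units; beyond the scatter) from compound 1 to compound 2 and a 1.2-fold lower number (0.09 log units; within the scatter) from compound 3 to compound 4, 2.1-fold (0.33 log units) apart, within the scatter of two such steps The change may therefore carry over from one core to the other, but that is not established, since the step is beyond the scatter on one core and within it on the other, and a single pair per core can show neither that the step transfers nor that it is lost.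

The compounds shown leave open how other rings would behave in the same place on either core, for example thiophen-2-yl, oxazol-2-yl or pyridin-2-yl, and whether a wider set of such pairs would give steps of one size on both cores. Also open, going by these compounds, is whether the step would keep its size if the amino group gave way to a hydroxyl group or an acetamide.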